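The source may hold more compounds than are shown below. What is called first, only, known or untested is meant among the compounds shown, and "the series" means these compounds.

Series notes. Compound 1 `CC(C)=CCC1Cc2c(OCc3ccccc3)cc(=O)n(CCCO)c2CC1(C)C` and compound 2 `CC(C)=CCC1Cc2c(OCCCNS(=O)(=O)c3ccc([N+](=O)[O-])cc3)cc(=O)n(CCCO)c2CC1(C)C` share a core and have both been run in a functional assay on PANC-1 cells (Homo sapiens) for inhibition, read by MTT assay, with a stated time of 24 h, tested at 10 uM; on this read-out lower numbers stand for less inhibition and higher numbers for more inhibition at the one concentration tested (going by the name of the read-out). Compound 1 gives 11.1% in this assay, the lower of the two numbers recorded. Compound 2 gives 17.3% in this assay, a number that sits within the scatter of compound 1, so the two are not distinguishable on these data.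

Compound 3 `CC(C)=CCC1Cc2c(OC(=O)Nc3ccc(Cl)c(Cl)c3)cc(=O)n(CCCO)c2CC1(C)C` has not yet been run. Set against compound 1 the structural change is (3,4-dichlorophenyl)carbamoyl in place of benzyl on an oxygen on an aromatic ring. Within the data shown here, no measured pair that differs in one place is available to calibrate a step of this kind, so the expectation rests only on the two numbers recorded, both of which are low. The step from compound 1 to compound 3 is expected to be small, a number 6.9 percentage points higher from compound 1 to compound 3 (within the scatter), and not beyond the scatter. Compound 3 is expected to give about 18% in this assay, with a range from 5% to 35%.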

Compound 3, a percentage reported as inhibition, at one concentration (the size of the read-out at that concentration, not a potency): 1.8%
Beside the measured number, compound 3's estimate is 16.2 percentage points above it; measured number below the stated range.
By their numbers in this assay, from the lowest: compounds 3, 1 and 2 (each within the scatter of the next, the first and the last beyond it).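

Among these compounds, at the oxygen on an aromatic ring, (3,4-dichlorophenyl)carbamoyl in place of benzyl gives the first one-place comparison, and in this assay it reads as a number 9.3 percentage points lower from compound 1 to compound 3 (within the scatter), so the two groups cannot be told apart on this read-out. This position therefore accepts a group with more heavy atoms, plus a hydrogen-bond donor and a hydrogen-bond acceptor that benzyl does not have, without a separable difference from compound 1. No measurement bears on the reason for this result.

Still open, from the compounds shown here alone, is whether an amine or a carboxylic acid at the end of a longer chain on this oxygen would move the number beyond the scatter of compound 1. Plain phenylcarbamoyl at this place would also be needed to separate the carbamoyl link from the two chlorine atoms.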